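This account rests on a few compounds, and the source may have more. Where it says the series, first, only, none or still open, it means among the compounds named here.

compound 1 `COc1cc(OC)c2sc(-c3ccc(N/C=C\C(=O)c4ccc(OC)c(O)c4)c(C)c3)nc2c1` at 14300 nM
compound 2 `COc1cc(OC)c2sc(-c3ccc(N/C=C\C(=O)c4ccc(OC)c([N+](=O)[O-])c4)c(C)c3)nc2c1` at 12100 nM

Both values come from a functional assay on A549 cells (Homo sapiens) for antiproliferative activity, read by sulforhodamine B assay, with a stated time of 48 h (a lower number here means a stronger inhibitor, a higher number a weaker inhibitor), and lie within the scatter of each other, so compound 2 cannot be ranked against compound 1. Among the measured compounds shown here, the one measured step is small: a 1.2-fold lower number from compound 1 to compound 2 (0.07 log units; within the scatter) with nitro in place of hydroxy on an aromatic carbon.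

Compound 3 `COc1ccc(C(=O)/C=C\Nc2ccc(-c3nc4cc(OC)c(OC)c(OC)c4s3)cc2C)cc1[N+](=O)[O-]` keeps the rest of compound 2 and changes one place: methoxy in place of hydrogen on an aromatic carbon with methoxy in place of hydrogen on an aromatic carbon of the shared core. For the measured compounds named here, the measured step lies elsewhere in the molecule, and no measured pair tests this change, so the guidance is weak. No step beyond the scatter is therefore expected in this assay for now. The expected move is a 1.2-fold lower number from compound 2 to compound 3 (0.08 log units; within the scatter) and no more than that. For compound 3 the estimated value is 10000 nM with an expected range from 3000 nM to 30000 nM as a rough guide.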

Compound 3, half-maximal inhibitory concentration: 9100 nM
Compound 3: middle estimate off by 1.1-fold (0.04 log units), on the high side, and the stated range covers the measured number.
By their numbers in this assay, from the lowest: compounds 3, 2 and 1 (each within the scatter of the next).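

Among the compounds shown here, the earlier step lay elsewhere in the molecule, so this is the first look at the shared core, at a carbon of its six-membered aromatic ring that is ortho to two methoxy groups. In this assay, methoxy in place of hydrogen on this carbon gives a 1.3-fold lower number from compound 2 to compound 3 (0.12 log units; within the scatter), so this single change leaves the number within the scatter and shows neither a clear gain nor a clear loss. No outside measurement bears on this result.

As far as these compounds go, whether a different group on this same carbon, such as an amine, a carboxylic acid or a longer chain like ethoxy, would move the number beyond the scatter remains open. No step shown so far lies beyond the scatter, so it also remains unknown which part of these molecules most affects the number.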